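Bromine on the Benzyl Group: Compound 3 to Compound 4

This account rests on a few compounds, and the source may have more. Where it says the series, first, only, none or still open, it means among the compounds named here.

Of the compounds shown here, three sharing one core have been tested in an ADME assay on GES1 cells (Homo sapiens) for inhibition, read by MTT assay, with a stated time of 72 h; a lower number here means a stronger inhibitor, a higher number a weaker inhibitor. Compound 1 `Cc1cc(Nc2cc(-c3ccc(Cl)cc3)[nH]n2)n2nc(SCc3ccc(Br)cc3)nc2n1` gives 28200 nM in this assay. Compound 2 `Cc1cc(Nc2cc(-c3ccccc3)[nH]n2)n2nc(SCc3nc4ccccc4[nH]3)nc2n1` gives 27800 nM, and compound 3 `Cc1cc(Nc2cc(-c3ccccc3)[nH]n2)n2nc(SCCc3ccccc3)nc2n1` gives 37400 nM. The number for compound 3 is numerically the highest of the three, but its gaps to compound 1 and to compound 2 both lie within the scatter, so the three stand together.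

For the measured compounds named here, the only single-place step among them, a 1.3-fold higher number from compound 2 to compound 3 (0.13 log units; within the scatter), stays within the scatter as well. Compound 4 `Cc1cc(Nc2cc(-c3ccccc3)[nH]n2)n2nc(SCc3ccc(Br)cc3)nc2n1` is now to be measured in this assay. It differs from compound 3 by 4-bromophenyl in place of benzyl on a saturated chain carbon bound to a sulfur. Compound 1 carries the same (4-bromobenzyl)sulfanyl group, though with a different ring on the pyrazole, and its value of 28200 nM sits close to that of compound 3. Going by the values given here, the single step known at this position, from a benzimidazolyl group to a benzyl group, moved the number only within the scatter.

On this basis the step of a 1.2-fold lower number from compound 3 to compound 4 (0.10 log units; within the scatter) is expected to stay within the scatter. Compound 4 is therefore estimated at 30000 nM in this assay. The range for compound 4 is expected to run from 12000 nM to 75000 nM.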

Compound 4, half-maximal inhibitory concentration: 39300 nM
Compound 4: middle estimate off by 1.3-fold (0.12 log units), on the low side; the range from low to high includes it.
By their numbers in this assay, from the lowest: compounds 2, 1, 3 and 4 (each within the scatter of the next).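

In this assay, the change from phenethylsulfanyl to (4-bromobenzyl)sulfanyl gives a 1.1-fold higher number from compound 3 to compound 4 (0.02 log units; within the scatter) and the change from the 1H-benzimidazol-2-yl group to 4-bromophenyl on the same saturated chain carbon bound to a sulfur gives a 1.4-fold higher number from compound 2 to compound 4 (0.15 log units; within the scatter), so compounds 2, 3 and 4 stand together and this position has so far tolerated all three groups without a step beyond the scatter. The result also gives the first single-place step away from that position, a 1.4-fold higher number from compound 1 to compound 4 (0.14 log units; within the scatter) with hydrogen in place of chloro on an aromatic carbon, and that step too stays within the scatter. No measurement shown offers an explanation for these results.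

For the compounds shown here, every group at this position so far carries an aromatic ring, so it remains open whether a plain methyl, a longer chain ending in an amine or one ending in a carboxylic acid would stand with them or move the number beyond the scatter. With no step here beyond the scatter, the compounds shown also leave open which change, at this position or on the aromatic carbon, could separate any of them in this assay at all.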